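Methoxy on the anilide ring: lipophilicity notes

The compounds below may be only part of what the source reports. "The series", "measured", "known", "first", "only" and "open" are said of these compounds alone.

Measured so far:
compound 1 `O=C(CC1SCCNC1=O)Nc1ccccc1`: 0.8
compound 2 `COc1ccccc1NC(=O)CC1SCCNC1=O`: 0.8

In a physicochemical assay for lipophilicity, using the shake flask method, measured as octanol-water partition, at pH 7.4 (a lower number here means a more polar compound, a higher number a more lipophilic compound), compound 1 gives 0.8. It stands level with compound 2 at the digits shown, and compound 2 is its nearest neighbour in the series; the two values lie within the scatter of each other.

The next compound is compound 3 `COc1cccc(NC(=O)CC2SCCNC2=O)c1`. Against compound 1 the change is methoxy in place of hydrogen on an aromatic carbon.

Within the data shown here, the one measured step that bears on this is the one from compound 1 to compound 2, where the step of no change at the digits printed from compound 1 to compound 2 (within the scatter) put a methoxy in place of hydrogen on an aromatic carbon of the same ring. That step left the distribution coefficient unchanged within the scatter. Compound 3 carries the same group on the same ring, only on a carbon meta to a large group. Among the measured compounds shown here, no measured pair speaks to that placement, so the single step from compound 1 to compound 2 is the only guide.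

The expectation is therefore a step of about a number 0.10 log units higher from compound 1 to compound 3 (within the scatter), that is, none beyond the scatter. For compound 3 the estimated value in this assay is 0.9, with a range from 0.5 to 1.3.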

Compound 3, distribution coefficient: 1
The estimate for compound 3 lay 0.10 log units below the measured number; measured number inside the range.
By their numbers in this assay, from the lowest: compounds 1, 2 and 3 (each within the scatter of the next).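

In this assay, among these compounds, methoxy in place of hydrogen on an aromatic carbon, here meta to a large group, gives a number 0.20 log units higher from compound 1 to compound 3 (within the scatter) and so extends the reading to a placement that no earlier pair covered, with the step still inside the scatter. Alongside no change at the digits printed from compound 1 to compound 2 (within the scatter) and with compound 2 and compound 3 standing within the scatter of each other, the read-out does not separate the two placements of methoxy on this ring. No measurement at hand accounts for either step.

Going by these compounds, whether an amine or a carboxylic acid on the same ring, or a longer chain such as ethoxy in place of methoxy, would move the distribution coefficient beyond the scatter stays open. The compounds shown also leave open how methoxy behaves on the remaining carbons of the ring, and whether a second methoxy on the same ring would still leave the value within the scatter of compound 1.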